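The compounds below may be only part of what the source reports. "The series", "measured", "known", "first", "only" and "open" are said of these compounds alone.

In a functional assay on MCF7 cells (Homo sapiens) for antiproliferative activity, read by MTT assay, with a stated time of 72 h (on this read-out lower numbers stand for stronger inhibition and higher numbers for weaker inhibition), compound 1 (`CCN1CCN(c2cc(C)c3cc(NC(=O)c4cccc(C)c4)ccc3n2)CC1`) gives 7800 nM, compound 2 (`CCN1CCN(c2cc(C)c3cc(NC(=O)c4ccccc4F)ccc3n2)CC1`) gives 32600 nM, and compound 3 (`CCN1CCN(c2cc(C)c3cc(NC(=O)c4ccc(F)c(F)c4)ccc3n2)CC1`) gives 5230 nM. Compound 3 stands level with compound 1 and clear of compound 2: a 1.5-fold lower number from compound 1 to compound 3 (0.17 log units; within the scatter) lies within the scatter, whereas a 6.2-fold lower number from compound 2 to compound 3 (0.79 log units; beyond the scatter) lies beyond it.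

The next change leads to compound 4 (`CCN1CCN(c2cc(C)c3cc(NC(=O)c4ccc5ccccc5n4)ccc3n2)CC1`), with quinolin-2-yl in place of 3,4-difluorophenyl on a carbonyl carbon. The rest of the structure stays the same.

All three measured steps were made at this same place. Besides the step to compound 3 already noted, a 4.2-fold higher number from compound 1 to compound 2 (0.62 log units; beyond the scatter) also lies beyond the scatter. Both steps of modest size involve compound 2, while compound 1 and compound 3 do not separate. Among the measured compounds shown here, the measured compounds offer no direct precedent for the entering group, as none carries an aromatic ring with a hetero atom at this place.

No step beyond the scatter is therefore expected in this assay, with a slight lean towards a higher number and a wide margin on both sides. The estimated step is a 1.5-fold higher number from compound 3 to compound 4 (0.18 log units; within the scatter). For compound 4 the expected value is 8000 nM, with an estimated range from 2500 nM to 22000 nM.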

Compound 4, half-maximal inhibitory concentration: 7060 nM
Beside the measured number, compound 4's estimate is 1.1-fold (0.05 log units) above it, and the stated range covers the measured number.
By their numbers in this assay, from the lowest: compounds 3, 4 and 1 (each within the scatter of the next); then compound 2.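

In this assay, among the compounds shown here, quinolin-2-yl is the first group at this place with an aromatic ring containing a hetero atom, and compound 4 stays level with the two best-placed carbon-only aryl amides: a 1.3-fold higher number from compound 3 to compound 4 (0.13 log units; within the scatter) and a 1.1-fold lower number from compound 1 to compound 4 (0.04 log units; within the scatter). The position on the carbonyl carbon therefore accepts a second fused ring, the larger count of 10 heavy atoms and a hydrogen-bond acceptor without any step beyond the scatter from either compound. The only separation remains the one set by the 2-fluorophenyl group, now seen against a third partner: a 4.6-fold lower number from compound 2 to compound 4 (0.66 log units; beyond the scatter), which leaves compound 2 as the weakest of the four and the only one apart from the others.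

A pyridin-2-yl or naphthalen-2-yl group at this place would show whether the ring nitrogen and the second fused ring can be told apart, since quinolin-2-yl brings both at once. No measurement on hand explains why quinolin-2-yl sits level with 3,4-difluorophenyl and 3-methylphenyl, or why 2-fluorophenyl stands apart.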